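The compounds below may be only part of what the source reports. "The series", "measured", "known", "first", "only" and "open" are said of these compounds alone.

Within the data shown here, in a functional assay on BXPC-3 cells (Homo sapiens) for antiproliferative activity, read by MTT assay, with a stated time of 24 h (a lower number here means a stronger inhibitor, a higher number a weaker inhibitor), the two measured members sit close together. Among the measured compounds shown here, compound 1 `CCn1c(C(=O)N[C@@H](C)C(=O)OC)ccc1C(CC)(CC)c1ccc(OCS(=O)(=O)c2ccccc2)c(C)c1` gives 17900 nM, and compound 2 `CCn1c(C(=O)N[C@H](C)CO)ccc1C(CC)(CC)c1ccc(OCS(=O)(=O)c2ccccc2)c(C)c1` gives 10000 nM, so compound 2 stands within the scatter of the only other number available. Compound 3 `CCn1c(C(=O)NCCCO)ccc1C(CC)(CC)c1ccc(OCS(=O)(=O)c2ccccc2)c(C)c1` keeps the shared core and changes only the chain on the amide-type nitrogen: 3-hydroxypropyl in place of 1-(hydroxymethyl)ethyl on an amide-type nitrogen. In words, 3-hydroxypropyl stands in place of 1-(hydroxymethyl)ethyl, and the defined stereocentre is lost.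

For the measured compounds named here, one measured step bears on this, as it changes the same amide-type nitrogen substituent: a 1.8-fold lower number from compound 1 to compound 2 (0.25 log units; within the scatter). Going by the values given here, that step stays within the scatter, but it is weak evidence, since no measured compound carries the 3-hydroxypropyl group and no measured pair isolates the loss of the stereocentre. Among the compounds with values here, with so small a step as the only guide, no direction is favoured and no shift beyond the scatter is expected in this assay. The estimated change is a 1.1-fold higher number from compound 2 to compound 3 (0.04 log units; within the scatter). For compound 3 the expected value is 11000 nM, with an estimated range of 5000 nM to 25000 nM.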

Compound 3, half-maximal inhibitory concentration: 26600 nM
Compound 3: middle estimate off by 2.4-fold (0.38 log units), on the low side; measured number outside the range, above it.
By their numbers in this assay, from the lowest: compounds 2, 1 and 3 (each within the scatter of the next, the first and the last beyond it).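

In this assay, the amide-type nitrogen substituent now gives its first step beyond the scatter, though a modest one (a 2.7-fold higher number from compound 2 to compound 3 (0.42 log units; beyond the scatter)). The 1-(hydroxymethyl)ethyl and 3-hydroxypropyl groups have the same atoms and the same donor and acceptor counts, so this change in how the atoms are joined, with loss of the defined stereocentre, is enough to move the number. The step from the ester-bearing chain stays within the scatter (a 1.5-fold higher number from compound 1 to compound 3 (0.17 log units; within the scatter)), so compound 1 and compound 3 cannot be ordered, and nothing available accounts for the difference between compound 2 and compound 3.

The compounds shown do not separate the effect of moving the hydroxyl along the chain from that of losing the stereocentre, as the opposite stereoisomer of the 1-(hydroxymethyl)ethyl group and an unbranched 2-hydroxyethyl chain are not among them. Going by these compounds, it also remains open how this position would respond to a longer chain such as 4-hydroxybutyl, or to a terminal amine or carboxylic acid in place of the hydroxyl.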